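Swapping a Benzofuran for a Thiophene on a Nucleoside Core

The compounds below may be only part of what the source reports. "The series", "measured", "known", "first", "only" and "open" are said of these compounds alone.

Three nucleoside analogues were tested in a functional assay on HL-60 cells (Homo sapiens) for antiproliferative activity, read by XTT assay, with a stated time of 72 h; a higher number here means a weaker inhibitor, a lower number a stronger inhibitor. Compound 1 `O=c1[nH]cnc2c1c(-c1ccsc1)cn2[C@@H]1O[C@H](CO)[C@@H](O)[C@H]1O` carries a thiophen-3-yl group, and in this assay compound 1 gives 12000 nM. Compound 2 `O=c1[nH]cnc2c1c(-c1cc3ccccc3o1)cn2[C@@H]1O[C@H](CO)[C@@H](O)[C@H]1O` carries a 1-benzofuran-2-yl group in the same place, and for compound 2 the result is only a limit of the assay, > 20000 nM. The change between them, (thiophen-3-yl in place of 1-benzofuran-2-yl on an aromatic carbon), gave an at least 1.6-fold lower number from compound 2 to compound 1 (0.22 log units; that floor lies within the scatter). Compound 3 `Cc1nc(N)c2c(-c3cc4ccccc4o3)cn([C@@H]3O[C@H](CO)[C@@H](O)[C@H]3O)c2n1` carries the 1-benzofuran-2-yl group on a different core, and for compound 3 the result is again a limit of the assay, > 20000 nM. The difference between the two cores is not broken down here. Compound 4 `Cc1nc(N)c2c(-c3ccsc3)cn([C@@H]3O[C@H](CO)[C@@H](O)[C@H]3O)c2n1`, not yet measured, carries the same change as compound 1 but on the core of compound 3: thiophen-3-yl in place of 1-benzofuran-2-yl on an aromatic carbon. Among the compounds with values here, since the earlier step rests on a limit (the limit of > 20000 nM in this assay, at which 2 of the 3 values shown sit), its true size is unknown, and the core difference has no measured step of its own. The step from compound 3 to compound 4 is therefore estimated as an at least 1.4-fold lower number from compound 3 to compound 4 (0.15 log units; that floor lies within the scatter), placed beside the earlier one. Compound 4 is expected to give about 14000 nM, with a range estimated from 5000 nM to 40000 nM.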

Compound 4, half-maximal inhibitory concentration: > 20000 nM
Compound 4 gave a limit, no number; the forecaster's own chance of this, stated with the estimate: 40%; middle value at least 1.4-fold (0.15 log units) from the limit.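

Compound 3 and compound 4 both give only a limit in this assay, not a number, so the step between them cannot be read: the limit of > 20000 nM in this assay, at which 3 of the 4 values shown sit.

The compounds shown leave open how far thiophen-3-yl in place of 1-benzofuran-2-yl changes the result on the core of compound 3, and how the two cores compare.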